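An Ester Group Replaces a Propargyl Ether

The source may report more compounds than this note shows. Statements on the series, on what has been measured and on what is new or still open speak of the compounds shown alone.

Compound 1: `C#CCOc1cc(/C=C/C(=O)c2ccc(OC)c3c2OC(C)(C)C=C3)ccc1OC` – > 10000 nM
Compound 2: `COc1ccc(/C=C/C(=O)c2ccc(OC)c3c2OC(C)(C)C=C3)cc1OCCO` – 8750 nM
Compound 3: `CCCCC(=O)Oc1cc(/C=C/C(=O)c2ccc(OC)c3c2OC(C)(C)C=C3)ccc1OC` – 240 nM

In a functional assay on K562 cells (Homo sapiens) for cytotoxicity, read by MTT assay (on this read-out higher numbers stand for weaker inhibition and lower numbers for stronger inhibition), the number for compound 1 is only a limit of the assay (the limit of > 10000 nM in this assay, at which 1 of the 3 values shown sits), not a measured value. Compound 4, `COc1ccc(/C=C/C(=O)Oc2cc(/C=C/C(=O)c3ccc(OC)c4c3OC(C)(C)C=C4)ccc2OC)cc1`, differs from compound 1 in one place: (2-(4-methoxyphenyl)ethenyl)carbonyl in place of propargyl on an oxygen on an aromatic ring. Going by the values given here, two measured steps bear on this. An ester group entering on that same oxygen gave an at least 41-fold lower number from compound 1 to compound 3 (1.61 log units; beyond the scatter) and a 36-fold lower number from compound 2 to compound 3 (1.56 log units; beyond the scatter), both large, both beyond the scatter. Compound 4 also carries an ester on that oxygen, so a similarly large lowering is expected; compound 4 is estimated at 350 nM, range 80 nM to 1500 nM, meaning an expected at least 28-fold lower number from compound 1 to compound 4 (1.45 log units; beyond the scatter).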

Compound 4, half-maximal inhibitory concentration: 380 nM
Beside the measured number, compound 4's estimate is 1.1-fold (0.04 log units) below it; measured number inside the range.
By their numbers in this assay, from the lowest: compounds 3 and 4 (each within the scatter of the next); then compound 2. At a limit, above all of these: compound 1.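

The ester on this oxygen tolerates a very different group: butyl can give way to 2-(4-methoxyphenyl)ethenyl, with its six-membered aromatic ring, and the change stays small (a 1.6-fold higher number from compound 3 to compound 4 (0.20 log units; within the scatter)). This larger ester also stands well clear of both ethers (a 23-fold lower number from compound 2 to compound 4 (1.36 log units; beyond the scatter); an at least 26-fold lower number from compound 1 to compound 4 (1.42 log units; beyond the scatter)). The last of these steps is only a floor, as compound 1 gives a limit: the limit of > 10000 nM in this assay, at which 1 of the 4 values shown sits.

The compounds shown leave open whether a short acetyl ester, or a free hydroxyl on this ring, would keep such low numbers. They also leave open how a chain ending in an amine or a carboxylic acid would behave on this oxygen.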